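The compounds below may be only part of what the source reports. "The series", "measured", "known", "first", "only" and "open" are said of these compounds alone.

Compound 1 `COc1cc(NC(C)CCCNC(=O)NNC(=O)Nc2cccc(F)c2)c2ncccc2c1`: in a functional assay on L1210 cells (Mus musculus) for inhibition, read by MTT assay, with a stated time of 72 h (a lower number here means a stronger inhibitor, a higher number a weaker inhibitor), compound 1 gives 108000 nM.
Compound 2 `COc1cc(NC(C)CCCNC(=O)Nc2ccc(F)cc2)c2ncccc2c1`: in this assay compound 2 gives 18000 nM.

Of these two numbers compound 1 stands highest; its nearest neighbour is compound 2, reached by a 6.0-fold lower number from compound 1 to compound 2 (0.78 log units; beyond the scatter). Compound 3 `COc1cc(NC(C)CCCNC(=O)Nc2ccc(O)cc2)c2ncccc2c1` has not yet been measured. It differs from compound 1 as follows: 4-hydroxyphenyl in place of ((3-fluorophenyl)carbamoyl)amino on an amide-type nitrogen. Within the data shown here, one measured step bears on this change, a 6.0-fold lower number from compound 1 to compound 2 (0.78 log units; beyond the scatter), which likewise removes the ((3-fluorophenyl)carbamoyl)amino group in favour of a single aromatic ring on the same amide-type nitrogen. Among the measured compounds shown here, the 4-hydroxyphenyl group of compound 3 has no measured counterpart, so its own contribution cannot be read from the data. For compound 3 a step toward lower numbers in this assay, beyond the scatter, is therefore expected, a 4.3-fold lower number from compound 1 to compound 3 (0.64 log units; beyond the scatter). Compound 3 is estimated at 25000 nM, with a range from 8000 nM to 80000 nM.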

Compound 3, half-maximal inhibitory concentration: 21000 nM
For compound 3 the middle estimate is 1.2-fold (0.08 log units) above the measured one, and the stated range covers the measured number.
By their numbers in this assay, from the lowest: compounds 2 and 3 (each within the scatter of the next); then compound 1.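

In this assay, 4-hydroxyphenyl in place of ((3-fluorophenyl)carbamoyl)amino on the amide-type nitrogen gives a 5.1-fold lower number from compound 1 to compound 3 (0.71 log units; beyond the scatter) and thus a second step in the same direction, so the lower number at this place is no longer tied to the 4-fluorophenyl group alone. Hydroxy in place of fluoro on an aromatic carbon gives a 1.2-fold higher number from compound 2 to compound 3 (0.07 log units; within the scatter) and so, in this measurement, the two groups cannot be told apart at this position. Nothing measured here explains either step.

Going by these compounds, it remains open whether an amine or a carboxylic acid in place of the hydroxy group would also leave the number unchanged within the scatter. On these data alone, it is equally open how an unsubstituted phenyl group or a longer chain on the same amide-type nitrogen would compare.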